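A few compounds are considered here, and "the series" means these few. Any claim that something is new, unique, unknown or untested is made for them only; others in the source may bear on it.

Measured compounds:
- compound 1, `CCN(CC)C(=O)CN(c1ccc(C)cc1)S(=O)(=O)c1ccc(OC(F)(F)F)cc1`: 1820 nM
- compound 2, `CCN(C(=O)CN(c1cc(N(C)C)ccc1Cl)S(=O)(=O)c1ccc(OC)c(OC)c1)c1ccn(C)n1`: 7 nM

Compound 1 was tested in a functional assay on CHO cells for inhibition of Orexin receptor type 2 (Homo sapiens), read by FLIPR and calcium flux (on this read-out lower numbers stand for stronger inhibition and higher numbers for weaker inhibition), and gave 1820 nM. Of the two numbers in hand this is the higher one; compound 2, with 7 nM, sits far lower, and the gap between the two is well beyond the scatter. The two compounds differ at several places at once, so no single change can be read from that gap; it only shows that the shared core can reach a much lower number than compound 1 does.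

Compound 3, `CCN(CC)C(=O)CN(c1ccc(C)cc1)S(=O)(=O)c1ccc(OC)cc1`, is the next compound to be measured. It differs from compound 1 in one place: methyl in place of trifluoromethyl on an oxygen on an aromatic ring. For the measured compounds named here, no measured pair shows this change on its own, so nothing in the data fixes its size or direction. Without such a comparison the account expects no step beyond the scatter, and takes the step of a 1.2-fold lower number from compound 1 to compound 3 (0.08 log units; within the scatter) as the working assumption. On that basis compound 3 is estimated to give 1500 nM, with a range from 500 nM to 5000 nM.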

Compound 3, half-maximal inhibitory concentration: 661 nM
Compound 3: middle estimate off by 2.3-fold (0.36 log units), on the high side; the measured number falls inside the stated range.
By their numbers in this assay, from the lowest: compound 2; then compound 3; then compound 1.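

In this assay the change from trifluoromethoxy to methoxy comes with a 2.8-fold lower number from compound 1 to compound 3 (0.44 log units; beyond the scatter), so this place on the aromatic ring responds to what sits on the oxygen, and the three fluorines of compound 1 are not needed to reach the lower number. For the compounds shown here, this is the first step that can be read on its own: the earlier comparison changed several places at once and could tie no part of its gap to any one group, whereas here a modest share of change is tied to a single substitution on the core of compound 1. Going by these compounds alone, nothing measured so far accounts for the direction or the size of this step, and the step itself is all that can be said of it.

The compounds shown leave open how a longer chain such as ethyl on the same oxygen would read, or how a hydroxyl or an amine would read in place of the whole methoxy group. They also leave open whether the same change gives a step of similar size when the rest of the molecule is different.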